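Extending the Sulfur Chain of Compound 3

The source may hold more compounds than are shown below. What is called first, only, known or untested is meant among the compounds shown, and "the series" means these compounds.

Measured in a functional assay on PC-3 cells (Homo sapiens) for inhibition, read by MTT assay, with a stated time of 48 h; a higher number here means a weaker inhibitor, a lower number a stronger inhibitor:
Compound 1 `CCSc1nnc(-c2cc(OC)c(OC)c(OC)c2)n1-c1ccc(OC)cc1` gives 57700 nM
Compound 2 `COc1ccc(-n2c(SCC(=O)C3CC3)nnc2-c2cc(OC)c(OC)c(OC)c2)cc1` gives 37200 nM
Compound 3 `CCSc1nnc(-c2cc(OC)c(OC)c(OC)c2)n1-c1ccc(N(C)C)cc1` gives 46200 nM

Compound 3 stands within the scatter of both other compounds, so these three values set no order. Compound 4 `COc1ccc(C(=O)CSc2nnc(-c3cc(OC)c(OC)c(OC)c3)n2-c2ccc(N(C)C)cc2)cc1O` differs from compound 3 in one place (see ((3-hydroxy-4-methoxyphenyl)carbonyl in place of methyl on a saturated chain carbon bound to a sulfur)). Within the data shown here, the closest precedent is the change at the same place (namely a 1.6-fold lower number from compound 1 to compound 2 (0.19 log units; within the scatter)), which also brings in a carbonyl group. The other measured change (namely a 1.2-fold lower number from compound 1 to compound 3 (0.10 log units; within the scatter)) does not bear on this step, since compound 3 and compound 4 both carry dimethylamino. Among the measured compounds shown here, no measured compound has the entering aromatic ring. Only a small move toward a lower number is therefore expected, and the expected step in this assay is a 1.8-fold lower number from compound 3 to compound 4 (0.25 log units; within the scatter) by this estimate. Compound 4 is estimated at 26000 nM with an expected range from 7000 nM to 70000 nM in all.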

Compound 4, half-maximal inhibitory concentration: > 100000 nM
Compound 4: a limit, no number; the forecaster's own chance of this, stated with the estimate: 10%; middle value at least 3.8-fold (0.58 log units) away from the limit.
By their numbers in this assay, from the lowest: compounds 2, 3 and 1 (each within the scatter of the next). At a limit, above all of these: compound 4.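

Compound 4 gives only a limit, not a number: the limit of > 100000 nM in this assay, at which 1 of the 4 values shown sits.

Even so, this position is shown to matter in this assay: the (3-hydroxy-4-methoxyphenyl)carbonyl change gives an at least 2.1-fold higher number from compound 3 to compound 4 (0.33 log units; beyond the scatter). The cyclopropylcarbonyl change at the same place gave only a 1.6-fold lower number from compound 1 to compound 2 (0.19 log units; within the scatter), so a carbonyl group there does not by itself bring a step beyond the scatter.

The compounds shown leave open how far compound 4 lies past its limit. They also do not tell whether a plain benzoyl group, or a carboxylic acid on this chain, would behave likewise.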